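Swapping a Cyclopropyl Group and the Cell Tolerance Expected

This account rests on a few compounds, and the source may have more. Where it says the series, first, only, none or still open, it means among the compounds named here.

Measured so far:
Compound 1 `CC(C)(C)OC(=O)N1CCC2(CC1)N=C(N)N=C(N)N2Cc1cccc(Cl)c1`: > 100000 nM in an ADME assay on MDCK cells (Canis lupus familiaris) for cytotoxicity, read by microscopy, with a stated time of 6 days (on this read-out lower numbers stand for higher toxicity in this test and higher numbers for lower toxicity in this test), a limit of the test rather than a number.
Compound 2 `CCCN1C(N)=NC(N)=NC12CCN(C(=O)C1CC1)CC2`: > 100000 nM in this assay, again a limit rather than a number.

Compound 2 therefore stands at the ceiling of what this assay can report, level with compound 1, since the limit of > 100000 nM in this assay, at which 2 of the 2 values shown sit, holds for both values shown; no difference between them can be claimed. The unmeasured compound 3 `CCCN1C(N)=NC(N)=NC12CCN(C(=O)NCCC(=O)OCC)CC2` differs from compound 2 in one place: (2-(ethoxycarbonyl)ethyl)amino in place of cyclopropyl on a carbonyl carbon. Within the data shown here, with no measured step between any two compounds to lean on, the expectation for this assay is a step of no size beyond the scatter, in neither direction. Compound 3 is therefore expected to give 100000 nM, with a range from 50000 nM to 200000 nM. That expectation corresponds to the step of a number no higher from compound 2 to compound 3 (the limit leaves the size open), and most likely the test will again report only a limit.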

Compound 3, minimum cytotoxic concentration: > 100000 nM
Compound 3 gave a limit, no number; the forecaster's own chance of this, stated with the estimate: 85%; the middle value lies on the limit itself.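

Among these compounds, compound 2 and compound 3 both give only a limit rather than a number in this assay, so no step between them can be read: the limit of > 100000 nM in this assay, at which 3 of the 3 values shown sit.

The compounds shown leave open whether any change to the shared core would give a readable number in this assay.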